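This account rests on a few compounds, and the source may have more. Where it says the series, first, only, none or still open, it means among the compounds named here.

Among the measured compounds shown here, compound 2 `COc1ccc(C(=O)/C=C/c2cc(-c3cc(OC)c(OC)c(OC)c3)n[nH]2)cc1OC` gives 1910 nM in a functional assay on K562 cells (Homo sapiens) for inhibition, read by sulforhodamine B assay, with a stated time of 48 h (a lower number here means a stronger inhibitor of growth, a higher number a weaker inhibitor of growth), the highest of the two numbers so far. For the measured compounds named here, compound 1 `COc1cc(-c2cc(/C=C/C(=O)c3ccc(N)cc3)[nH]n2)cc(OC)c1OC` gives 720 nM in this assay, and the step of a 2.7-fold higher number from compound 1 to compound 2 (0.42 log units; beyond the scatter) is the only measured change at the carbonyl carbon. Compound 3 `COc1cc(-c2cc(/C=C/C(=O)c3ccc(F)c(F)c3)[nH]n2)cc(OC)c1OC` differs from compound 2 by 3,4-difluorophenyl in place of 3,4-dimethoxyphenyl on a carbonyl carbon. Going by the values given here, that measured step bears on the present change only in that it concerns the same carbonyl carbon; it exchanged one group for another, and neither of those is the 3,4-difluorophenyl that enters here, so no measured step tests this exchange directly. With one modest step at this carbon and nothing on the difluoro group, the expectation for compound 3 in this assay is a step of a 1.3-fold lower number from compound 2 to compound 3 (0.10 log units; within the scatter), not beyond the scatter. Compound 3 is therefore estimated at 1500 nM, with a range from 500 nM to 4500 nM.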

Compound 3, concentration for 50% growth inhibition: 3310 nM
For compound 3 the middle estimate is 2.2-fold (0.34 log units) below the measured one; the measured number falls inside the stated range.
By their numbers in this assay, from the lowest: compound 1; then compounds 2 and 3 (each within the scatter of the next).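

At the carbonyl carbon, the exchange of 3,4-dimethoxyphenyl for 3,4-difluorophenyl does not separate the two compounds in this assay: a 1.7-fold higher number from compound 2 to compound 3 (0.24 log units; within the scatter), even though the counts go from 2 hydrogen-bond acceptors to 0 on this group. The 4-aminophenyl group now stands apart from both other groups, with a 4.6-fold higher number from compound 1 to compound 3 (0.66 log units; beyond the scatter), which adds to the earlier step and leaves compound 1 as the strongest inhibitor of growth among the three. No measured evidence is available to explain this separation.

Still open, going by these compounds, is whether the lower number of compound 1 belongs to the amine itself, which a hydroxyl or an acetamide in its place would help to test. Also open, on these data alone, is whether this order holds beyond a single cell line.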